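The compounds below may be only part of what the source reports. "The series", "measured", "known", "first", "only" and "open" are said of these compounds alone.

In a functional assay on MDA-MB-231 cells (Homo sapiens) for cytotoxicity, read by MTT assay, with a stated time of 96 h (on this read-out lower numbers stand for stronger inhibition and higher numbers for weaker inhibition), the measured compounds read as follows
- compound 1 `[N-]=[N+]=NCC/C(=C(\c1ccccc1)c1ccc(OCCO)cc1)c1ccccc1` gives > 100000 nM (a limit)
- compound 2 `NCC/C(=C(\c1ccccc1)c1ccc(OCCO)cc1)c1ccccc1` gives 14500 nM
- compound 3 `NCCOc1ccc(/C(=C(/CCN)c2ccccc2)c2ccccc2)cc1` gives 13400 nM

Compound 1 gives a limit and not a number, and it stands at the limit of > 100000 nM in this assay, at which 1 of the 3 values shown sits, in this series. For the measured compounds named here, compound 2 at 14500 nM and compound 3 at 13400 nM lie within the scatter of each other, so compound 2 shares its place with the only other compound that has a number.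

The next compound is compound 4 `O=C(NCC/C(=C(\c1ccccc1)c1ccc(OCCO)cc1)c1ccccc1)Oc1ccccc1` and it carries phenoxycarbonyl in place of hydrogen on an amine nitrogen on compound 2. In words, 2-aminoethyl becomes 2-((phenoxycarbonyl)amino)ethyl.

Going by the values given here, two measured steps bear on this change. Among the compounds with values here, at the same chain end there is an at least 6.8-fold lower number from compound 1 to compound 2 (0.83 log units; beyond the scatter) and this is the only step here that alters that amino group. At the other chain end there is a 1.1-fold lower number from compound 2 to compound 3 (0.03 log units; within the scatter) and it touches the change only loosely. Neither step tests a phenoxycarbonyl group, so the size stays uncertain. Going by an at least 6.8-fold lower number from compound 1 to compound 2 (0.83 log units; beyond the scatter) as the one precedent for losing the free amino group, a move towards weaker inhibition is expected, though a smaller one. The estimate is a 2.1-fold higher number from compound 2 to compound 4 (0.32 log units; beyond the scatter) in this assay as the expected step. Compound 4 is expected at an estimated 30000 nM with a range from 9000 nM to 100000 nM as its likely span.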

Compound 4, half-maximal inhibitory concentration: 62300 nM
Estimate against measurement, compound 4: 2.1-fold (0.32 log units) below, within the range that was stated.
By their numbers in this assay, from the lowest: compounds 3 and 2 (each within the scatter of the next); then compound 4. At a limit, above all of these: compound 1.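

In this assay, for the compounds shown here, the change at this amine nitrogen gives a 4.3-fold higher number from compound 2 to compound 4 (0.63 log units; beyond the scatter), which shows for the first time that a group added to the nitrogen, with the nitrogen itself kept, moves the number towards weaker inhibition; the earlier steps had only replaced the azido group with amino at this chain end or changed the other chain end. The comparison with the azido compound reads an at least 1.6-fold lower number from compound 1 to compound 4 (0.20 log units; that floor lies within the scatter), and since that floor lies within the scatter, the step does not put the two compounds in a firm order. Compound 1 gives a limit and not a number: the limit of > 100000 nM in this assay, at which 1 of the 4 values shown sits.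

The compounds shown leave open whether the shift belongs to the carbonyl or to the phenyl ring, a question that an acetyl group or a benzyl group on the same nitrogen would separate. They also leave open whether a longer chain carrying the amine, or a carboxylic acid in its place, would keep the level of compound 2, and whether phenoxycarbonyl on either amino group of compound 3 would act in the same way.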